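Swapping pyridin-2-yl for phenyl in a cytotoxicity series

This account rests on a few compounds, and the source may have more. Where it says the series, first, only, none or still open, it means among the compounds named here.

Measured compounds:
compound 1 `S=C(Nc1ccc(Br)cc1)OCCc1ccccn1` — 37000 nM
compound 2 `COc1ccc(NC(=S)OCCc2ccccn2)cc1` — 48000 nM

Of the compounds shown here, two have been tested in an ADME assay on MT4 cells (Homo sapiens) for cytotoxicity, read by MTT assay (a higher number here means that more compound is tolerated, a lower number that less compound is tolerated), and they sit close together: compound 1 gives 37000 nM in this assay, while compound 2 gives 48000 nM. Going by the values given here, the only measured step, a 1.3-fold higher number from compound 1 to compound 2 (0.11 log units; within the scatter), leaves the two numbers indistinguishable, so compound 2 cannot be called better or worse tolerated than compound 1; it simply holds the higher of the two readings, with compound 1 within the scatter of it.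

Compound 3 `COc1ccc(NC(=S)OCCc2ccccc2)cc1` is the next compound. It differs from compound 2 by phenyl in place of pyridin-2-yl on a saturated chain carbon, two bonds along the chain from an oxygen on an unsaturated carbon, a change on the chain rather than on the aromatic ring that was varied before. Among the compounds with values here, no measured step touches this part of the shared core, so the step from compound 1 to compound 2 gives no direct guide; it only shows that one aromatic change left this assay unmoved. On that slender basis compound 3 is expected to stay close to compound 2, with an estimated step of a 1.2-fold lower number from compound 2 to compound 3 (0.08 log units; within the scatter). The estimate for compound 3 is 40000 nM, with a range from 15000 nM to 100000 nM.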

Compound 3, half-maximal cytotoxic concentration: 36000 nM
For compound 3 the middle estimate is 1.1-fold (0.05 log units) above the measured one; measured number inside the range.
By their numbers in this assay, from the lowest: compounds 3, 1 and 2 (each within the scatter of the next).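

In this assay the exchange at this position, phenyl in place of pyridin-2-yl on a saturated chain carbon, two bonds along the chain from an oxygen on an unsaturated carbon, amounts to a 1.3-fold lower number from compound 2 to compound 3 (0.12 log units; within the scatter) and so cannot be told apart from no change at all. Going by these compounds alone, this is the first reading from this part of the shared core, and it shows that the ring nitrogen of pyridin-2-yl can give way to carbon here without a difference beyond the scatter, just as the aromatic change in a 1.3-fold higher number from compound 1 to compound 2 (0.11 log units; within the scatter) showed none on the other side of the molecule. Nothing available bears on why the reading holds here.

From the compounds shown here alone, it remains open whether a more distant replacement at this position, such as an amine or a carboxylic acid in place of phenyl, or a longer chain carrying the phenyl, would shift the number beyond the scatter. Within the data shown here, it is also open whether bromo on the aromatic ring together with phenyl on the chain would stay as close as the single changes do.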